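Furan to Indole at the Biaryl Position: Cytotoxicity

This account rests on a few compounds, and the source may have more. Where it says the series, first, only, none or still open, it means among the compounds named here.

Compound 3 `CC(C)N(Cc1cccc(OCCCCCC(=O)O)c1)C(=O)c1ccc(-c2ccco2)cc1` is one of three compounds from this series whose cytotoxicity has been measured. In an ADME assay on BJ cells (Homo sapiens) for cytotoxicity, read by CellTiter-Glo and resazurin assay, with a stated time of 72 h (a lower number here means that less compound is needed, a higher number that more compound is needed for the effect), compound 3 gives only a limit, > 26000 nM. Compound 1 `CC(=O)c1cccc(-c2ccc(C(=O)N(Cc3cccc(OCCCCCC(=O)O)c3)C(C)C)cc2)c1` also reaches only a limit in this assay, > 26000 nM. Compound 2 `CC(C)N(Cc1cccc(OCCCCCC(=O)O)c1)C(=O)c1ccc(-c2ccoc2)cc1` likewise stops at a limit, > 26000 nM. All three therefore stand at the same place, as the limit of > 26000 nM in this assay, at which 3 of the 3 values shown sit, records. The steps between them, a step that the two limits leave unreadable from compound 1 to compound 2, a step that the two limits leave unreadable from compound 1 to compound 3 and a step that the two limits leave unreadable from compound 2 to compound 3, cannot be sized, since each end rests on a limit rather than a number.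

Compound 4 `CC(C)N(Cc1cccc(OCCCCCC(=O)O)c1)C(=O)c1ccc(-c2ccc3[nH]ccc3c2)cc1` differs from compound 3 in one place: 1H-indol-5-yl in place of furan-2-yl on an aromatic carbon. For the measured compounds named here, none of the measured steps gives a readable size for exchanging the group on this aromatic carbon, so the data offer no measured direction for the change. What they do show is that every variation of this group so far has left the cytotoxicity beyond the reach of the assay. The expected step, a step that the limit leaves unreadable from compound 3 to compound 4, is therefore taken to lie within the scatter. Compound 4 is accordingly estimated at 30000 nM, with a range from 10000 nM to 100000 nM, and most likely the assay will again report only a limit.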

Compound 4, half-maximal effective concentration: > 26000 nM
Compound 4 ended at the assay's limit; the forecaster's own chance of this, stated with the estimate: 75%; the middle value lies beyond the limit too.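

Compound 4, like compound 1, compound 2 and compound 3, ends at a limit in this assay, so none of its steps to those three compounds can be read: the limit of > 26000 nM in this assay, at which 4 of the 4 values shown sit.

The compounds shown leave open at what concentration any of them would reach the half-maximal effect, and whether any group on this aromatic carbon would yield a readable value.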